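Phenoxymethyl replacing dichlorophenoxy on a weak nicotinic antagonist

The compounds below may be only part of what the source reports. "The series", "measured", "known", "first", "only" and "open" are said of these compounds alone.

Of the compounds shown here, three have been measured in an in vitro functional assay on HEK ts201 cells for antagonist activity at Neuronal acetylcholine receptor; alpha4/beta2 (Homo sapiens), read by fluorescence and calcium flux; on this read-out lower numbers stand for stronger inhibition and higher numbers for weaker inhibition. Compound 1 `O=C(OC1CCCN(CCCc2ccccc2)C1)c1ccccc1-c1ccccc1` gives 6500 nM. Compound 2 `CC1CC(=O)N(c2ccccc2C(=O)OCC2CCCN(CCCCOc3ccc(Cl)c(Cl)c3)C2)C1=O` gives 12300 nM, the highest of the two single numbers, with compound 1 its nearest neighbour within the usual scatter, so no order between them can be read. Compound 3 `O=C(OCC1CCCN(CCCc2ccccc2)C1)c1ccccc1C(F)(F)F` is represented by several entries, (the several entries of compound 3 in this assay, 7940 nM; 8000 nM (2 entries)), which agree closely with each other and sit near the other two; compound 3 gives 7940 nM; 8000 nM (2 entries).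

The step under consideration leads from compound 2 to compound 4 `CC1CC(=O)N(c2ccccc2C(=O)OCC2CCCN(CCCCCOc3ccccc3)C2)C1=O`, a compound not yet measured in this assay. The change is phenoxymethyl in place of 3,4-dichlorophenoxy on a saturated chain carbon, four bonds along the chain from an amine nitrogen in a ring: the two chlorines leave and the chain to the aromatic ring grows by one saturated carbon, while the shared core of compound 2 is kept.

For the measured compounds named here, no step between measured compounds is available to calibrate this exchange, and nothing in the data points to a direction. Since every measured compound sits at weak inhibition, compound 4 is expected to stay in the same region, and the step of a 1.2-fold higher number from compound 2 to compound 4 (0.09 log units; within the scatter) is estimated to be small, not clearly beyond the scatter. For compound 4 the estimate in this assay is 15000 nM, with a range from 6000 nM to 40000 nM.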

Compound 4, half-maximal inhibitory concentration: 17000 nM
Estimate against measurement, compound 4: 1.1-fold (0.05 log units) below; the measured number falls inside the stated range.
By their numbers in this assay, from the lowest: compounds 1, 2 and 4 (each within the scatter of the next, the first and the last beyond it).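

For the compounds shown here, the exchange of 3,4-dichlorophenoxy for phenoxymethyl, on a saturated chain carbon, four bonds along the chain from an amine nitrogen in a ring, gives the first step that can be read at this position in this assay: a 1.4-fold higher number from compound 2 to compound 4 (0.14 log units; within the scatter). With the shared core kept, losing both chlorines and gaining one saturated chain carbon thus leaves compound 2 and compound 4 within the scatter of each other, so this position tolerates the combined change without any readable shift in the number, and inhibition remains weak. Nothing in the supporting data bears on why the number holds here.

The step joins two changes in one, so the compounds shown leave open what the chlorines and the extra chain carbon each contribute alone, and whether the two could offset each other. Also open, from the compounds shown here alone, is whether a different group at this place, such as an amine, a carboxylic acid or a much shorter chain ending in a single chlorine-bearing phenyl ring, would move the number beyond the scatter.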